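The source may report more compounds than this note shows. Statements on the series, on what has been measured and on what is new or still open speak of the compounds shown alone.

Among the compounds with values here, compound 3 `CCOC(=O)Cc1n[nH]c(NC(=O)c2ccc(Cl)cc2)n1` gives 58.5% in a functional assay on the whole organism (strain albino) for inhibition, with Rattus norvegicus as the target, read by paw edema, with stated times of 30 min and 3 h, at a dose of 5 mg/kg by the oral route (on this read-out lower numbers stand for less inhibition and higher numbers for more inhibition at the one dose given (going by the name of the read-out)), and no other measured compound gives more: compound 2 `CCOC(=O)Cc1n[nH]c(N)n1` gives 51.8%, within the scatter of compound 3, while compound 1 `Nc1nc(CC(=O)O)n[nH]1` gives 48.1%, a gap beyond the scatter. Within the data shown here, the only measured step, a number 3.7 percentage points higher from compound 1 to compound 2 (within the scatter), lies within the scatter and concerns the ethyl group, not the aromatic ring. Compound 4 `CCOC(=O)Cc1n[nH]c(NC(=O)c2ccc(OC)cc2)n1` differs from compound 3 by methoxy in place of chloro on an aromatic carbon. Among the measured compounds shown here, no measured step changes the six-membered aromatic ring, so the data give no size or direction for the step in this assay. Compound 4 is therefore expected near compound 3, at 58% with a range from 45% to 70%, an expected step of a number 0.5 percentage points lower from compound 3 to compound 4 (within the scatter) that stays within the scatter.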

Compound 4, a percentage reported as inhibition, in the whole organism at one dose (the size of the read-out at that dose, not a potency): 56%
The estimate for compound 4 lay 2 percentage points above the measured number; low and high end bracket the measured number.
By their numbers in this assay, from the lowest: compounds 1, 2, 4 and 3 (each within the scatter of the next, the first and the last beyond it).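

In this assay, methoxy in place of chloro on the aromatic carbon para to a large group gives a number 2.5 percentage points lower from compound 3 to compound 4 (within the scatter). Within the data shown here, this is the first measured change on the aromatic ring, and it shows that this position accepts a group with one more heavy atom and a hydrogen-bond acceptor without a shift beyond the scatter. Nothing available explains why the read-out holds across this change.

As far as these compounds go, whether an amine or a nitrile at this position would also leave the number in place remains open. So does whether chloro and methoxy stay alike at other doses, since only one dose is given.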